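Methyl in Place of Chloro on a Thiophene Ring

The compounds below may be only part of what the source reports. "The series", "measured", "known", "first", "only" and "open" are said of these compounds alone.

Compound 1 `COc1cc(NCc2ccc(Cl)s2)ccc1-c1cnco1` — 43200 nM
Compound 2 `COc1cc(/N=C/c2ccc(F)cc2)ccc1-c1cnco1` — > 100000 nM, a limit of the assay
Compound 3 `COc1cc(/N=C/C=C/c2ccccc2)ccc1-c1cnco1` — > 100000 nM, a limit of the assay

In an ADME assay on Huh-7 cells (Homo sapiens) for cytotoxicity, read by MTT assay, with a stated time of 96 h (a higher number here means that more compound is tolerated, a lower number that less compound is tolerated), compound 1 gives 43200 nM. For the measured compounds named here, this is the only actual number among the three measured compounds. For compound 2, > 100000 nM is a limit of the assay and not a number. For compound 3, > 100000 nM is likewise a limit of the assay. Going by the values given here, the one piece of evidence on hand is the limit of > 100000 nM in this assay, at which 2 of the 3 values shown sit. Compound 1 therefore stands alone with a measured concentration, while the other two compounds sit at that limit.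

Compound 4 `COc1cc(NCc2ccc(C)s2)ccc1-c1cnco1` has not yet been measured in this assay. It differs from compound 1 in a single spot: methyl in place of chloro on an aromatic carbon. Among the compounds with values here, no measured pair of compounds shows this kind of change, so there is no step to lean on. The step from compound 1 to compound 4 in this assay is expected to be small, within the usual scatter or only slightly toward more compound being tolerated, as a 1.3-fold higher number from compound 1 to compound 4 (0.10 log units; within the scatter). Compound 4 is estimated to give 55000 nM, with a range from 25000 nM to 120000 nM.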

Compound 4, half-maximal cytotoxic concentration: 34400 nM
Compound 4: middle estimate off by 1.6-fold (0.20 log units), on the high side, within the range that was stated.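

Going from 5-chlorothiophen-2-yl to 5-methylthiophen-2-yl, on the ring carbon next to the ring sulfur, gives a 1.3-fold lower number from compound 1 to compound 4 (0.10 log units; within the scatter) in this assay as the first direct reading of any single change in this set. At this position, then, chloro and methyl cannot be told apart in this read-out, and compound 1 and compound 4 both give actual numbers rather than a limit of the assay. Nothing on hand bears on why these two groups read alike.

Still open, on these data alone, is whether a larger or very different group at the same ring carbon, such as an ethyl chain, an amine or a carboxylic acid, would also leave the number within the scatter. Also open, as far as these compounds go, is whether methyl in place of chloro would read the same way on another ring.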